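The source may hold more compounds than are shown below. What is called first, only, known or untested is meant among the compounds shown, and "the series" means these compounds.

Compound 1 `CC1=CC[C@H](C(C)(C)NC(=S)N/N=C/c2ccccc2)CC1` carries a phenyl on a carbon with a double bond to nitrogen. In a functional assay on NCI-H460 cells (Homo sapiens) for inhibition, read by sulforhodamine B assay, with a stated time of 48 h (on this read-out lower numbers stand for stronger inhibition of growth and higher numbers for weaker inhibition of growth), compound 1 gives 13000 nM, the higher of the two numbers shown in this assay. Compound 2 `CC1=CC[C@H](C(C)(C)NC(=S)N/N=C/c2cccc(Cl)c2)CC1` gives 1400 nM in this assay, so chloro in place of hydrogen on an aromatic carbon brings a 9.3-fold lower number from compound 1 to compound 2 (0.97 log units; beyond the scatter). Compound 3 `COc1cc(/C=N/NC(=S)NC(C)(C)[C@H]2CC=C(C)CC2)ccc1O` reaches only a limit in this assay, > 100000 nM. That limit is the limit of > 100000 nM in this assay, at which 1 of the 3 values shown sits, the edge of what this assay reports.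

Compound 4 `CC1=CC[C@H](C(C)(C)NC(=S)N/N=C/c2ccco2)CC1` has not been measured in this assay. It differs from compound 1 by furan-2-yl in place of phenyl on a carbon with a double bond to nitrogen. Going by the values given here, neither measured step exchanges the aromatic ring itself: the step from compound 1 to compound 2 adds a substituent to the ring, and compound 3 differs from compound 1 in more than one place, so no measured step bears directly on this exchange. Without such a step, the account treats the ring exchange as likely to leave the number near that of compound 1, with wide uncertainty in either direction. Compound 4 is therefore expected to give about 15000 nM in this assay, within 4000 nM to 60000 nM. The expected step, a 1.2-fold higher number from compound 1 to compound 4 (0.06 log units; within the scatter), lies within the usual scatter.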

Compound 4, concentration for 50% growth inhibition: 13500 nM
Estimate against measurement, compound 4: 1.1-fold (0.05 log units) above, and the stated range covers the measured number.
By their numbers in this assay, from the lowest: compound 2; then compounds 1 and 4 (each within the scatter of the next). At a limit, above all of these: compound 3.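

In this assay, the exchange of the aromatic ring itself can now be read: furan-2-yl in place of phenyl on a carbon with a double bond to nitrogen gives a 1.0-fold higher number from compound 1 to compound 4 (0.02 log units; within the scatter). This position therefore accepts a five-membered aromatic ring with an oxygen as well as a six-membered aromatic ring of carbon only, with no difference that can be told from the numbers, whereas the chloro of compound 2 still sets that compound apart, as the other new step shows: a 9.6-fold higher number from compound 2 to compound 4 (0.98 log units; beyond the scatter). No measurement shown gives a reason for either step.

The compounds shown leave open whether the chloro would bring a similar step on the furan-2-yl ring, and how an amine or a carboxylic acid on the aromatic ring, or a pyridine ring in place of phenyl, would read in this assay. Compound 3 stays at a limit, > 100000 nM, and as it differs from compound 1 in more than one place, it cannot be tied to any single group.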